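Aryl swap at the chain end of compound 1

The source may report more compounds than this note shows. Statements on the series, on what has been measured and on what is new or still open speak of the compounds shown alone.

Compound 1 `COc1ccccc1/C=C/C(=O)/C=C/c1ccc(OCc2cn(CCCCOc3cc(=O)oc4ccccc34)nn2)c(OC)c1` gives 47% in a functional assay on COLO 205 cells (Homo sapiens) for inhibition, read by sulforhodamine B assay, with a stated time of 48 h, tested at 50 uM (on this read-out lower numbers stand for less inhibition of growth and higher numbers for more inhibition of growth at the one concentration tested), the lowest of the three numbers in hand. Compound 2 `COc1cc(/C=C/C(=O)/C=C/c2cccc3ccccc23)ccc1OCc1cn(CCCOc2cc(=O)oc3ccccc23)nn1` gives 64% and compound 3 `COc1cc(/C=C/C(=O)/C=C/c2ccco2)ccc1OCc1cn(CCCOc2cc(=O)oc3ccccc23)nn1` gives 59%; both lie above compound 1 by more than the scatter. Going by the values given here, compound 2 and compound 3 differ from compound 1 in more than one place, so no single step to them is defined. Among the compounds with values here, the only single step measured, a number 5 percentage points lower from compound 2 to compound 3 (within the scatter), exchanges one aryl group for another on the chain end and stays within the scatter.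

Compound 4 `COc1cc(/C=C/C(=O)/C=C/c2cc(OC)c(OC)c(OC)c2)ccc1OCc1cn(CCCCOc2cc(=O)oc3ccccc23)nn1` is compound 1 with one change: 3,4,5-trimethoxyphenyl in place of 2-methoxyphenyl on a double-bonded chain carbon bound to a double-bonded chain carbon. Within the data shown here, the one comparable aryl exchange, between compound 2 and compound 3, moved the number by a number 5 percentage points lower from compound 2 to compound 3 (within the scatter), so no large step is expected here either; the rise of compound 2 and compound 3 over compound 1 offers only a hint that other aryl groups score higher. Compound 4 is therefore estimated at 53%, range 38% to 68%, a step of a number 6 percentage points higher from compound 1 to compound 4 (within the scatter) that stays within the scatter.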

Compound 4, percent growth inhibition at one concentration: 60%
Beside the measured number, compound 4's estimate is 7 percentage points below it; the range from low to high includes it.
By their numbers in this assay, from the lowest: compound 1; then compounds 3, 4 and 2 (each within the scatter of the next).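

In this assay, going by these compounds alone, the step of a number 13 percentage points higher from compound 1 to compound 4 (beyond the scatter) is the first single exchange on a double-bonded chain carbon bound to a double-bonded chain carbon to pass beyond the scatter, whereas the earlier step of a number 5 percentage points lower from compound 2 to compound 3 (within the scatter) did not, so the aryl group at this place can affect growth inhibition. The gain is modest and rests on one pair, with 3,4,5-trimethoxyphenyl entering for 2-methoxyphenyl. Nothing available explains why this exchange moves the number.

The pair cannot separate the methoxy groups that enter from the loss of the 2-methoxy pattern, and a single concentration gives no dose-response. Also open, going by these compounds, is how this place would respond to an aryl group carrying a dimethylamino group or a carboxylic acid.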